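A few compounds are considered here, and "the series" means these few. Any claim that something is new, unique, unknown or untested is made for them only; others in the source may bear on it.

Measured compounds:
compound 1, `C[C@H]1C[C@H]1C(=O)N1CC2CNCC2C1`, 2000 nM;
compound 2, `C[C@@H]1C[C@H]1C(=O)N1CC2CNCC2C1`, 360 nM;
compound 3, `C[C@H]1C[C@@H]1C(=O)N1CC2CNCC2C1`, 13000 nM.

All three were tested in an assay on CHO cells for displacement of a labelled ligand from Neuronal acetylcholine receptor; alpha3/beta4 (Homo sapiens), read by scintillation counting, with a stated time of 2 h; on this read-out higher numbers stand for weaker inhibition and lower numbers for stronger inhibition. They share the same atoms and bonds and differ only in the spatial arrangement at the 2-methylcyclopropyl group. Compound 3 stands highest of the three numbers and is the weakest: there is a 6.5-fold higher number from compound 1 to compound 3 (0.81 log units; beyond the scatter) and a 36-fold higher number from compound 2 to compound 3 (1.56 log units; beyond the scatter), and the smaller gap a 5.6-fold lower number from compound 1 to compound 2 (0.74 log units; beyond the scatter) separates the other two. These steps are tied to the fact that one of compounds 1 and 3 is drawn with a defined configuration and the other without, at the place where they differ and (the fact that one of compounds 2 and 3 is drawn with a defined configuration and the other without, at the place where they differ).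

Compound 4, `CCC(=O)N1CC2CNCC2C1`, changes the acyl group itself: ethyl in place of 2-methylcyclopropyl on a carbonyl carbon. For the measured compounds named here, no measured step covers a change of atoms, only changes of configuration, so the measured steps give no direct guide. They do show that the shape of the 2-methylcyclopropyl group moves the number widely, and an ethyl group carries no such stereocentres. Since compound 3 with 13000 nM stands highest, a lower number is expected, with a 5.2-fold lower number from compound 3 to compound 4 (0.72 log units; beyond the scatter). Compound 4 is estimated at 2500 nM, between 500 nM and 12000 nM.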

Compound 4, inhibition constant: 2100 nM
Compound 4: middle estimate off by 1.2-fold (0.08 log units), on the high side; measured number inside the range.
By their numbers in this assay, from the lowest: compound 2; then compounds 1 and 4 (each within the scatter of the next); then compound 3.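

With ethyl on the carbonyl carbon, a group with no ring and no defined stereocentres, compound 4 lies on opposite sides of two of the 2-methylcyclopropyl compounds (a 6.2-fold lower number from compound 3 to compound 4 (0.79 log units; beyond the scatter); a 5.8-fold higher number from compound 2 to compound 4 (0.77 log units; beyond the scatter)) and level with the third (a 1.1-fold higher number from compound 1 to compound 4 (0.02 log units; within the scatter)). The 2-methylcyclopropyl group is therefore neither better nor worse than ethyl as such: the outcome of the swap depends on which drawn configuration it replaces, and only compound 2 has a lower number than compound 4. The available evidence concerns configuration only and gives no cause for these steps between different groups.

From the compounds shown here alone, it remains open whether methyl, a longer chain such as propyl, or a plain cyclopropyl would stay near compound 4 or move away from it. An amine on the acyl chain is equally unexplored here.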